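Replacing the Phenyl of Compound 1 with an Open Chain

A few compounds are considered here, and "the series" means these few. Any claim that something is new, unique, unknown or untested is made for them only; others in the source may bear on it.

Measured in a functional assay on KB cells (Homo sapiens) for cytotoxicity, read by MTT assay, with a stated time of 3 days; a lower number here means a stronger inhibitor, a higher number a weaker inhibitor:
Compound 1 `N#Cc1c(Nc2ccccc2)nc(SCc2nc3ccccc3[nH]2)nc1-c1ccccc1`: 2.9 nM
Compound 2 `N#Cc1c(Nc2ccccn2)nc(SCc2nc3ccccc3[nH]2)nc1-c1ccccc1`: 7.35 nM
Not yet measured: compound 3 `N#Cc1c(NNC(N)=S)nc(SCc2nc3ccccc3[nH]2)nc1-c1ccccc1`

Compound 1 holds the lower of the two numbers in this assay. Compound 3 differs from it as follows: a group of 4 heavy atoms (1 carbon, 2 nitrogen, 1 sulfur; no ring) in place of a group of 6 heavy atoms (6 carbon; one six-membered aromatic ring of carbon only), on a nitrogen on an aromatic ring. Going by the values given here, only one measured step bears on this place, a 2.5-fold higher number from compound 1 to compound 2 (0.40 log units; beyond the scatter), and it is modest. That step exchanged one aromatic ring for another, whereas the group entering compound 3 has no ring, so it is only a loose guide. A modest step towards a higher number is therefore expected in this assay. The expected change is a 2.8-fold higher number from compound 1 to compound 3 (0.44 log units; beyond the scatter). The estimate for compound 3 is 8 nM, with an expected range from 2 nM to 35 nM.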

Compound 3, half-maximal inhibitory concentration: 3 nM
For compound 3 the middle estimate is 2.7-fold (0.43 log units) above the measured one, within the range that was stated.
By their numbers in this assay, from the lowest: compounds 1 and 3 (each within the scatter of the next); then compound 2.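

In this assay the open chain on this nitrogen gives a 1.0-fold higher number from compound 1 to compound 3 (0.01 log units; within the scatter) and so cannot be told apart from the phenyl, which shows that this place accepts a group with no ring. Against the pyridin-2-yl the same chain gives a 2.5-fold lower number from compound 2 to compound 3 (0.39 log units; beyond the scatter) and thus holds the modest gain over that ring. Nothing available here explains this result.

The compounds shown leave open whether the sulfur counts, as a urea with oxygen in its place would tell. On these data alone, how a plain amine or a longer chain on this nitrogen would read also stays open.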